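Furan-3-yl Replaces Difluorophenyl on the Cyclopropane

The compounds below may be only part of what the source reports. "The series", "measured", "known", "first", "only" and "open" are said of these compounds alone.

Three compounds share one core and differ only in the aryl group on the cyclopropane. In a functional assay for agonist activity at G protein-coupled receptor 88 (Homo sapiens), read by HTRF and cAMP accumulation (a higher number here means that more compound is needed for the effect, a lower number that less compound is needed), compound 1 `CC[C@H](C)[C@H](N)CN(C(=O)[C@@H]1C[C@H]1c1cccc(Cl)c1)c1ccc(-c2ccccc2)cc1` gives 2200 nM, compound 2 `CC[C@H](C)[C@H](N)CN(C(=O)[C@@H]1C[C@H]1c1cc(F)cc(F)c1)c1ccc(-c2ccccc2)cc1` gives 960 nM, and compound 3 `CC[C@H](C)[C@H](N)CN(C(=O)[C@@H]1C[C@H]1c1ccc(F)cc1F)c1ccc(-c2ccccc2)cc1` gives 1300 nM. Compound 3 thus stands second highest of the three numbers, with its gaps to compound 2 and to compound 1 both within the scatter. Compound 4 `CC[C@H](C)[C@H](N)CN(C(=O)[C@@H]1C[C@H]1c1ccoc1)c1ccc(-c2ccccc2)cc1` carries the change (furan-3-yl in place of 2,4-difluorophenyl on a saturated ring carbon). For the measured compounds named here, the steps that bear on it are the earlier aryl exchanges, a 2.3-fold lower number from compound 1 to compound 2 (0.36 log units; beyond the scatter), a 1.7-fold lower number from compound 1 to compound 3 (0.23 log units; within the scatter) and a 1.4-fold higher number from compound 2 to compound 3 (0.13 log units; within the scatter), all small; a furan has no precedent here. Compound 4 is therefore expected to show no step beyond the scatter, estimated at 1800 nM in this assay with a range of 700 nM to 4500 nM, a step of a 1.4-fold higher number from compound 3 to compound 4 (0.14 log units; within the scatter).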

Compound 4, half-maximal effective concentration: 580 nM
For compound 4 the middle estimate is 3.1-fold (0.49 log units) above the measured one; measured number outside the range, below it.
By their numbers in this assay, from the lowest: compounds 4, 2, 3 and 1 (each within the scatter of the next, the first and the last beyond it).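

The aryl group at this position need not be a six-membered carbon ring: in this assay the smaller furan-3-yl gives lower numbers than 2,4-difluorophenyl (a 2.2-fold lower number from compound 3 to compound 4 (0.35 log units; beyond the scatter)) and 3-chlorophenyl (a 3.8-fold lower number from compound 1 to compound 4 (0.58 log units; beyond the scatter)). Furan-3-yl and 3,5-difluorophenyl cannot be told apart (a 1.7-fold lower number from compound 2 to compound 4 (0.22 log units; within the scatter)). Nothing at hand accounts for these steps. Open, as far as these compounds go, is whether the ring oxygen matters, which a thiophen-3-yl or a cyclopentyl group could test. Also open, from the compounds shown here alone, is whether a furan-2-yl or a pyridin-3-yl group would serve equally well here.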